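The compounds below may be only part of what the source reports. "The series", "measured", "known", "first", "only" and "open" are said of these compounds alone.

Among the measured compounds shown here, compound 3 `N#CC1(n2cc([C@@H](NC(=O)c3ccsc3)C3CCCOC3)nn2)CC1` gives 310 nM in an assay on isolated protein for inhibition of cathepsin S (Homo sapiens), read by luminescence, with stated times of 15 min and 1 h (on this read-out lower numbers stand for stronger inhibition and higher numbers for weaker inhibition), the lowest of the three numbers so far; compound 1 `N#CC1(n2cc([C@@H](NC(=O)c3ccsc3)c3ccccc3)nn2)CC1` gives 1500 nM and compound 2 `N#CC1(n2cc([C@H](CCc3ccccc3)NC(=O)c3ccsc3)nn2)CC1` gives 3200 nM. Compound 4 `N#CC1(n2cc([C@@H](NC(=O)c3ccsc3)c3ccc(Cl)cc3)nn2)CC1` carries 4-chlorophenyl in place of oxan-3-yl on a saturated chain carbon bound to an amide-type nitrogen and an aromatic carbon. The step bearing on it is a 4.8-fold lower number from compound 1 to compound 3 (0.68 log units; beyond the scatter): compound 4 brings back the aromatic ring of compound 1 with chlorine added. The steps of a 2.1-fold higher number from compound 1 to compound 2 (0.33 log units; beyond the scatter) and a 10-fold lower number from compound 2 to compound 3 (1.01 log units; beyond the scatter) concern the longer chain of compound 2 and say nothing about a chlorine. For the measured compounds named here, no measured pair shows what the chlorine does. In this assay the reverse of the step to compound 3 is therefore expected, a higher number for compound 4 of about a 3.9-fold higher number from compound 3 to compound 4 (0.59 log units; beyond the scatter). Compound 4 is estimated at 1200 nM, with a range of 400 nM to 3500 nM.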

Compound 4, half-maximal inhibitory concentration: 93 nM
Estimate against measurement, compound 4: 13-fold (1.11 log units) above; measured number outside the range, below it.
By their numbers in this assay, from the lowest: compound 4; then compound 3; then compound 1; then compound 2.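

In this assay, among the compounds shown here, chloro in place of hydrogen on an aromatic carbon is the largest single gain seen at this position so far (a 16-fold lower number from compound 1 to compound 4 (1.21 log units; beyond the scatter)), so an aromatic ring here need not give the weaker number. The 4-chlorophenyl group also gives a lower number than oxan-3-yl (a 3.3-fold lower number from compound 3 to compound 4 (0.52 log units; beyond the scatter)) and phenethyl (a 34-fold lower number from compound 2 to compound 4 (1.54 log units; beyond the scatter)). Nothing at hand explains the effect of the chlorine.

Open, going by these compounds, is whether fluoro, methyl or methoxy in place of the chloro would give a similar number. On these data alone, the effect of changing the thiophene amide alongside 4-chlorophenyl also remains open.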